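Swapping the aryl group on the triazinedione-bearing compound

The source may hold more compounds than are shown below. What is called first, only, known or untested is meant among the compounds shown, and "the series" means these compounds.

Measured compounds:
compound 1, `Fc1cc(Nc2cc(Nc3ccc(Cl)cc3)ncn2)ccc1Oc1ccncc1-c1cccnc1`, 240 nM
compound 2, `Cn1c(=O)c(C(=O)Nc2ccc(Oc3ccncc3-c3cccnc3)c(F)c2)nn(-c2cccc(C(F)(F)F)c2)c1=O`, 1950 nM

Of the compounds shown here, two have been measured in a functional assay on MKN-45 cells (Homo sapiens) for cytotoxicity, read by MTT assay, with a stated time of 72 h; on this read-out higher numbers stand for weaker inhibition and lower numbers for stronger inhibition. Compound 1 gives 240 nM, while compound 2 gives 1950 nM, the higher of the two numbers; the gap between them lies beyond the usual scatter, so compound 2 is the weaker of the pair in this assay. The two compounds share the same pyridinyl-substituted pyridyloxy-fluorophenyl portion but differ widely elsewhere, so no single change can be drawn from their values.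

Compound 3, `Cn1c(=O)c(C(=O)Nc2ccc(Oc3ccncc3-c3cccnc3)c(F)c2)nn(-c2ccc(F)c(Cl)c2)c1=O`, has not yet been measured. It differs from compound 2 only by 3-chloro-4-fluorophenyl in place of 3-(trifluoromethyl)phenyl on an aromatic nitrogen. Among the compounds with values here, no measured pair tracks this kind of exchange, so the expectation rests on the value of compound 2 alone. Since the change is confined to a group away from the shared portion, compound 3 is expected to stay close to compound 2 in this assay, with the step of a 1.3-fold lower number from compound 2 to compound 3 (0.11 log units; within the scatter) expected to be small and not clearly beyond the scatter. The estimate for compound 3 in this assay is 1500 nM, in a range from 450 nM to 5000 nM.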

Compound 3, half-maximal inhibitory concentration: 10100 nM
Compound 3: the middle estimate sits 6.7-fold (0.83 log units) below what was measured; measured number outside the range, above it.
By their numbers in this assay, from the lowest: compound 1; then compound 2; then compound 3.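

In this assay, within the data shown here, exchanging 3-(trifluoromethyl)phenyl for 3-chloro-4-fluorophenyl on the aromatic nitrogen gives a 5.2-fold higher number from compound 2 to compound 3 (0.71 log units; beyond the scatter), the first single change that can be read. It shows that the aryl group at this position matters to the read-out, since the step lies beyond the scatter although the rest of the molecule stays the same. Both groups are a six-membered aromatic ring of carbon only, with no hydrogen-bond donors or acceptors and no net charge, so the step comes with a change in the substituents on that ring rather than in these counted features, and nothing measured here bears on why the number rises.

The exchange removes the trifluoromethyl group and brings in chlorine and fluorine together, so the compounds shown cannot separate what each substituent contributes. Also open, going by these compounds, is how the aryl position would read in this assay with a plain phenyl ring, a phenyl ring carrying a methoxy group or an amine, or a short alkyl chain in its place.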